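Trifluoromethyl for Methoxy on the Aryl Nitrile

The source may hold more compounds than are shown below. What is called first, only, known or untested is meant among the compounds shown, and "the series" means these compounds.

Measured compounds:
- compound 1 `CNC(=O)c1ccc(-c2ccc3c(c2)C(C)(C)C(=O)N3c2ccc(C#N)c(OC)c2)cc1F`: 9700 nM
- compound 2 `CCn1c(=O)n(-c2ccc(C#N)c(C(F)(F)F)c2)c2ccccc21`: 3470 nM

Of the compounds shown here, two have been measured in a physicochemical assay for solubility; on this read-out higher numbers stand for higher solubility and lower numbers for lower solubility. Compound 1 gives 9700 nM, the higher of the two numbers. Compound 2, built on a different core and carrying a trifluoromethyl group, gives 3470 nM, a gap from compound 1 that lies beyond the usual scatter of this assay. Compound 1 and compound 2 differ in more than one place. Going by the values given here, no single-point step between measured compounds is available.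

The next compound to be measured is compound 3 `CNC(=O)c1ccc(-c2ccc3c(c2)C(C)(C)C(=O)N3c2ccc(C#N)c(C(F)(F)F)c2)cc1F`. It is made from compound 1 by one change: trifluoromethyl in place of methoxy on an aromatic carbon. The only hint to its likely effect is that compound 2, which also carries a trifluoromethyl group, sits below compound 1 in this assay.

On that basis a downward step is expected, from compound 1 to compound 3 estimated as a 2.4-fold lower number from compound 1 to compound 3 (0.38 log units; beyond the scatter), modest but likely beyond the scatter. Compound 3 is therefore expected to give about 4000 nM, with a plausible range from 1500 nM to 11000 nM.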

Compound 3, solubility: 6250 nM
Estimate against measurement, compound 3: 1.6-fold (0.19 log units) below, and the stated range covers the measured number.
By their numbers in this assay, from the lowest: compounds 2, 3 and 1 (each within the scatter of the next, the first and the last beyond it).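

In this assay, going by these compounds alone, trifluoromethyl in place of methoxy on this aromatic carbon, ortho to a cyano group, gives a 1.6-fold lower number from compound 1 to compound 3 (0.19 log units; within the scatter), so the single change leaves the read-out within the scatter on the core of compound 1. Within the data shown here, this is the first comparison in which only one place differs, and it shows that methoxy, with its hydrogen-bond acceptor, and trifluoromethyl, with no such acceptor and more heavy atoms, are not told apart by this read-out at this position. No measured property is available to account for this result.

As far as these compounds go, how other groups would behave on this aromatic carbon stays open, for example an amine, a carboxylic acid or a longer chain such as ethoxy. Also open is whether the same exchange of methoxy for trifluoromethyl would stay within the scatter on a different core, since the one step shown comes from the core shared by compound 1 and compound 3 alone.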